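The compounds below may be only part of what the source reports. "The series", "measured", "known", "first", "only" and "open" are said of these compounds alone.

The series gathers four compounds built on a shared core. Compound 1 `Oc1ccc(-c2cc(-c3ccsc3)cc(-c3cccc(O)c3)n2)cc1` was entered into an assay on isolated protein for inhibition of DNA topoisomerase 1 (Homo sapiens), with a stated time of 30 min, tested at 20 uM (on this read-out higher numbers stand for a stronger effect at the one concentration tested and lower numbers for a weaker effect), and gives "not determined" (no result reported), and compound 2 `Oc1cccc(-c2cc(-c3ccoc3)cc(-c3ccccc3O)n2)c1` likewise gives "not determined" (no result reported), so neither contributes a number. Going by the values given here, compound 3 `Oc1ccc(-c2cc(-c3ccoc3)cc(-c3ccccc3O)n2)cc1` is therefore the only member with a value in this assay, where compound 3 gives 3.9%, a weak effect at the single concentration tested. Among the compounds with values here, because no two measured compounds differ in one place, no measured step is available anywhere in the set, and compound 3 stands alone as the sole point of reference.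

Compound 4 `Oc1ccc(-c2cc(-c3ccoc3)cc(-c3cccc(O)c3)n2)cc1` has not yet been measured. It shares every atom with compound 3, joined differently: 3-hydroxyphenyl in place of 2-hydroxyphenyl on an aromatic carbon. The only anchor for an expectation is the value of compound 3 in this assay; nothing in the set shows how relocating the hydroxyl within this group bears on the read-out. The expected step is none beyond the usual scatter, and a number 1.1 percentage points higher from compound 3 to compound 4 (within the scatter) is the estimated size of that step. For compound 4 the estimated inhibition in this assay is 5%, with a range from -6% to 16%.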

Compound 4, a percentage reported as inhibition, at one concentration (the size of the read-out at that concentration, not a potency): 1.3%
Compound 4: the middle estimate sits 3.7 percentage points above what was measured; the measured number falls inside the stated range.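

Relocating the hydroxyl, with 3-hydroxyphenyl in place of 2-hydroxyphenyl on the aromatic carbon next to the ring nitrogen, gives the first measured step in this series in this assay, and that step is a number 2.6 percentage points lower from compound 3 to compound 4 (within the scatter). The earlier compounds shown here offered a single number and could say nothing about this position, whereas this pair shows that these two hydroxyl placements are not told apart at the one concentration tested, and both readings remain weak effects. No measured evidence on either compound bears on this outcome.

From the compounds shown here alone, compound 1 and compound 2 carry no number, so no comparison involving them can be read, and the contribution of the group at the other positions of the shared core stays unknown. Whether an amine or a carboxylic acid on this ring in place of the hydroxyl, or a longer chain at this same aromatic carbon, would move the read-out beyond the usual scatter remains open in the compounds shown here.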